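Swapping an allyl for a cyclohexyl on a curcumin-like enaminone

This account rests on a few compounds, and the source may have more. Where it says the series, first, only, none or still open, it means among the compounds named here.

Of the compounds shown here, two have been measured in a functional assay on Caco-2 cells (Homo sapiens), read by fluorescence, tested at 1 uM; on this read-out higher numbers stand for a weaker effect at the one concentration tested and lower numbers for a stronger effect. Compound 1 `CCC(C)NC(=C\C(=O)/C=C/c1ccc(OC(C)=O)c(OC)c1)/C=C/c1ccc(OC(C)=O)c(OC)c1` carries two acetylated phenol groups and a sec-butyl group on its amine nitrogen; in this assay compound 1 gives 95%. Compound 2 `C=CCNC(=C\C(=O)/C=C/c1ccc(O)c(OC)c1)/C=C/c1ccc(O)c(OC)c1` has free phenols and an allyl group on the same nitrogen; in this assay compound 2 gives 89%. These two numbers lie within the usual scatter of each other, so the data give no ground to rank compound 1 and compound 2, and both numbers point to only a weak effect at the concentration tested.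

Compound 3 `COc1cc(/C=C/C(=O)/C=C(/C=C/c2ccc(O)c(OC)c2)NC2CCCCC2)ccc1O` differs from compound 2 in one place: cyclohexyl in place of allyl on an amine nitrogen. Both compounds keep the free phenols and the shared core. No measured pair in this set isolates such a change on the amine nitrogen, so nothing shown here indicates in which direction, if any, the read-out should move.

The expectation for compound 3 in this assay is therefore a number close to that of compound 2, with the expected step of a number 1 percentage points higher from compound 2 to compound 3 (within the scatter) lying within the scatter. Compound 3 is estimated at 90%, with a range from 72% to 100%.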

Compound 3, a percentage reported as activity, at one concentration (the size of the read-out at that concentration, not a potency): 88%
Compound 3: the middle estimate sits 2 percentage points above what was measured; low and high end bracket the measured number.
By their numbers in this assay, from the lowest: compounds 3, 2 and 1 (each within the scatter of the next).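

In this assay, the first single change measured at this position, cyclohexyl in place of allyl on the amine nitrogen, gives a number 1 percentage points lower from compound 2 to compound 3 (within the scatter). This nitrogen can therefore carry either an open allyl group or a six-membered carbon ring, which has more heavy atoms and no double bond outside aromatic rings, and the read-out does not separate the two compounds. Nothing measured here offers an explanation for this result.

This single swap leaves open whether a quite different group on the same nitrogen, such as a phenyl ring or a longer chain ending in a carboxylic acid, would give a read-out beyond the usual scatter. Going by these compounds, compound 1 differs from compound 2 and compound 3 in more than one place, so the acetylated phenols cannot be separated from the sec-butyl group, and the effect of acetylation on its own remains unknown.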